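Side-chain swaps on a shared chromone-type core: compound 4

The source may hold more compounds than are shown below. What is called first, only, known or untested is meant among the compounds shown, and "the series" means these compounds.

Measured compounds:
compound 1 `COc1cc(OC)c2c(=O)c(OCCCCN3CCCC3)c(-c3cc(OC)c(OC)c(OC)c3)oc2c1` gives 10400 nM in a functional assay on MDA-MB-231 cells (Homo sapiens) for cytotoxicity, read by MTT assay, with a stated time of 38 h; a higher number here means a weaker inhibitor, a lower number a stronger inhibitor
compound 2 `COc1cc(OC)c2c(=O)c(OCC(=O)N/N=C/c3ccccc3F)c(-c3cc(OC)c(OC)c(OC)c3)oc2c1` gives 3400 nM in this assay
compound 3 `CCN(CC)CCCCOc1c(-c2cc(OC)c(OC)c(OC)c2)oc2cc(OC)cc(OC)c2c1=O` gives 13000 nM in this assay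

Compound 2 holds the lowest number of the three in this assay; its nearest neighbour is compound 1, a step of a 3.1-fold lower number from compound 1 to compound 2 (0.49 log units; beyond the scatter) separates them, and compound 3 lies furthest, with a 3.8-fold higher number from compound 2 to compound 3 (0.58 log units; beyond the scatter). Compounds 1 and 3 sit within the scatter of each other, a 1.3-fold higher number from compound 1 to compound 3 (0.10 log units; within the scatter).

Compound 4 `COc1cc(OC)c2c(=O)c(OCCCN3CCN(C)CC3)c(-c3cc(OC)c(OC)c(OC)c3)oc2c1` is not yet measured. It differs from compound 2 in the chain on the ether oxygen: a group of 9 heavy atoms (7 carbon, 2 nitrogen; one six-membered non-aromatic ring with 2 hetero atoms) in place of a group of 12 heavy atoms (8 carbon, 2 nitrogen, 1 oxygen, 1 fluorine; one six-membered aromatic ring of carbon only), on a saturated chain carbon bound to an oxygen on an aromatic ring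

The step that bears most directly on this change is a 3.8-fold higher number from compound 2 to compound 3 (0.58 log units; beyond the scatter), where the same hydrazone-bearing group gave way to an amine-terminated chain. The step of a 3.1-fold lower number from compound 1 to compound 2 (0.49 log units; beyond the scatter) shows the reverse direction. Both amine-bearing analogues, compound 1 and compound 3, sit well above compound 2. Compound 4 carries an amine-terminated chain as well, so a rise of similar size is expected, roughly back to the level of compound 1 and compound 3; the estimated step is a 2.9-fold higher number from compound 2 to compound 4 (0.47 log units; beyond the scatter). Compound 4 is therefore estimated at 10000 nM, with a likely range of 4000 nM to 25000 nM.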

Compound 4, half-maximal inhibitory concentration: 30100 nM
Estimate against measurement, compound 4: 3.0-fold (0.48 log units) below; measured number outside the range, above it.
By their numbers in this assay, from the lowest: compound 2; then compounds 1 and 3 (each within the scatter of the next); then compound 4.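

Within the amine-terminated chains, the terminal group on this ether chain now matters in this assay: compounds 1 and 3 sit within the scatter of each other, yet the 2-(4-methylpiperazin-1-yl)ethyl chain of compound 4 stands clear of both (a 2.9-fold higher number from compound 1 to compound 4 (0.46 log units; beyond the scatter); a 2.3-fold higher number from compound 3 to compound 4 (0.36 log units; beyond the scatter)). Replacing the hydrazone-bearing chain therefore costs more with this chain than the earlier amine analogues indicated (an 8.9-fold higher number from compound 2 to compound 4 (0.95 log units; beyond the scatter)), so a terminal amine alone does not set the number at this position. No measurement shown accounts for this difference.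

Compound 4 differs from compounds 1 and 3 in both the terminal amine and the length of the chain, so the two contributions remain inseparable in these steps. A 4-(4-methylpiperazin-1-yl)butyl chain would hold the chain of compounds 1 and 3 while changing only the amine, and a 3-(pyrrolidin-1-yl)propyl chain would hold the chain of compound 4 while testing a different amine.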